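Phenoxy for phenyl on the benzylic carbon: compound 4

This account rests on a few compounds, and the source may have more. Where it says the series, first, only, none or still open, it means among the compounds named here.

Measured compounds:
compound 1 `c1ccc(Cc2nnc3sc(-c4ccccc4Oc4ccccc4)nn23)cc1` gives 56.3% in a functional assay on the whole organism (strain Wistar) for inhibition, with Rattus norvegicus as the target, read by paw edema, with stated times of 30 min and 3 h, at a dose of 20 mg/kg by the oral route; a higher number here means more inhibition at the dose given (going by the name of the read-out), a lower number less inhibition
compound 2 `c1ccc(Cc2nnc3sc(Cc4cc5ccccc5[nH]4)nn23)cc1` gives 41% in this assay
compound 3 `c1ccc(OCc2nnc3sc(-c4ccccc4Oc4ccccc4)nn23)cc1` gives 63.3% in this assay

Compound 2 stands lowest of the three in this assay; compound 1 is nearest and compound 3 furthest, both beyond the scatter above it. Compound 4 `c1ccc(OCc2nnc3sc(Cc4cc5ccccc5[nH]4)nn23)cc1` differs from compound 2 by phenoxy in place of phenyl on a saturated chain carbon bound to an aromatic carbon. Within the data shown here, one measured step bears on this change, a number 7 percentage points higher from compound 1 to compound 3 (within the scatter), and it lies within the scatter. The same change on compound 2 is therefore expected to produce a step of about that size, a number 6 percentage points higher from compound 2 to compound 4 (within the scatter), upward but not beyond the scatter. Compound 4 is estimated at 47%, with a range from 35% to 60%.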

Compound 4, a percentage reported as inhibition, in the whole organism at one dose (the size of the read-out at that dose, not a potency): 50.5%
Estimate against measurement, compound 4: 3.5 percentage points below, and the stated range covers the measured number.
By their numbers in this assay, from the lowest: compounds 2, 4, 1 and 3 (each within the scatter of the next, the first and the last beyond it).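

In this assay phenoxy in place of phenyl now reads as a number 9.5 percentage points higher from compound 2 to compound 4 (within the scatter) on a second core, so the change no longer rests on a single pair. The two steps agree in size: the same change on two cores in this assay, a number 7 percentage points higher (within the scatter) from compound 1 to compound 3 and a number 9.5 percentage points higher (within the scatter) from compound 2 to compound 4, 2.5 percentage points apart, within the scatter of two such steps. Neither step separates the change from the scatter, so this position shows a reproducible step size but no resolved gain.

Whether the change truly alters inhibition stays undecided. Going by these compounds, how an amine, a carboxylic acid or a longer chain would read on the saturated chain carbon bound to an aromatic carbon also stays open.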